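The compounds below may be only part of what the source reports. "The series", "measured", "known", "first", "only" and "open" are said of these compounds alone.

Compound 2 `COC(=O)[C@@H](N=[N+]=[N-])[C@@H]1O[C@@H](n2cnc3nc(NC(C)=O)nc(Cl)c32)[C@@H]2OC[C@H](OCc3ccccc3)[C@]2(OCc2ccccc2)[C@@H]1OCc1ccccc1` gives 103% in an ADME assay on A549 cells (Homo sapiens) for cytotoxicity, read by MTT assay, with a stated time of 24 h, tested at 0.2 ug/mL (on this read-out lower numbers stand for a stronger effect and higher numbers for a weaker effect at the one concentration tested), the higher of the two numbers in hand; compound 1 `CC(=O)Nc1nc(Cl)c2c(ncn2[C@@H]2O[C@@H]([C@H](N=[N+]=[N-])C(=O)OCc3ccccc3)[C@@H](OCc3ccccc3)[C@@]3(OCc4ccccc4)[C@@H](OCc4ccccc4)CO[C@@H]23)n1` gives 88.5%, and the step of a number 14.5 percentage points higher from compound 1 to compound 2 (beyond the scatter) came with hydrogen in place of phenyl on a saturated chain carbon bound to an oxygen next to a carbonyl group. Compound 3 `COC(=O)[C@H](N=[N+]=[N-])[C@@H]1O[C@@H](n2cnc3nc(NC(C)=O)nc(Cl)c32)[C@@H]2OC[C@H](OCc3ccccc3)[C@]2(OCc2ccccc2)[C@@H]1OCc1ccccc1` keeps every atom and bond of compound 2: the two compounds have the same atoms and bonds; at least one stereo element is drawn with a configuration in one of them and without one in the other: 1 of 8 stereo elements differ; a stereocentre at a saturated chain carbon is drawn S in compound 2 and R in compound 3. Among the compounds with values here, no measured step bears on a change of configuration alone; the one step in hand concerns a different change. With nothing to point either way, a step of about no change at the digits printed from compound 2 to compound 3 (within the scatter) is estimated, nothing beyond the scatter. Compound 3 is expected to give about 103%, within 88% to 112%.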

Compound 3, a percentage reported as activity, at one concentration (the size of the read-out at that concentration, not a potency): 103%
For compound 3 middle estimate and measured number coincide at the digits printed, within the range that was stated.
By their numbers in this assay, from the lowest: compound 1; then compounds 2 and 3 (each within the scatter of the next).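

In this assay, within the data shown here, the change from S to R at the saturated chain carbon comes with no change at the digits printed from compound 2 to compound 3 (within the scatter) and gives the first reading on configuration; the earlier step concerned the ester group instead. At this one concentration, the two methyl esters are not told apart. This reading carries one caution: the fact that one of compounds 2 and 3 is drawn with a defined configuration and the other without, at the place where they differ

On these data alone, whether the benzyl ester of compound 1 behaves the same way under this change stays open. Also open, as far as these compounds go, is what a carboxylic acid in place of the ester, or an amine in place of the azide, would give.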